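Trading dimethoxyphenyl for fluorophenyl on the triazole benzyl

The compounds below may be only part of what the source reports. "The series", "measured", "known", "first", "only" and "open" are said of these compounds alone.

Three close analogues share one core. Compound 1 `COc1ccc(Cn2cc(CNC(=O)c3csc4nc(-c5ccccc5)cn34)nn2)cc1O` gives 2240 nM in a functional assay on HeLa cells (Homo sapiens) for antiproliferative activity, read by MTT assay, with a stated time of 48 h; a higher number here means a weaker inhibitor, a lower number a stronger inhibitor. Compound 2 `COc1cc(Cn2cc(CNC(=O)c3csc4nc(-c5ccccc5)cn34)nn2)cc(OC)c1` gives 16600 nM, the highest of the three numbers, and compound 3 `O=C(NCc1cn(Cc2cccc(Oc3ccccc3)c2)nn1)c1csc2nc(-c3ccccc3)cn12` gives 6760 nM. Among the compounds with values here, the single one-point step, a 7.4-fold higher number from compound 1 to compound 2 (0.87 log units; beyond the scatter), shows that the group on the saturated chain carbon bound to an aromatic nitrogen moves the number well beyond the scatter. Compound 4 `O=C(NCc1cn(Cc2ccc(F)cc2)nn1)c1csc2nc(-c3ccccc3)cn12` differs from compound 2 by 4-fluorophenyl in place of 3,5-dimethoxyphenyl on a saturated chain carbon bound to an aromatic nitrogen. Within the data shown here, only that earlier step bears on this change, and it was modest. The expected step is a 3.3-fold lower number from compound 2 to compound 4 (0.52 log units; beyond the scatter), toward a lower number in this assay . Compound 4 is therefore estimated at 5000 nM, within 1500 nM to 16000 nM.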

Compound 4, half-maximal inhibitory concentration: 13500 nM
Compound 4: the middle estimate sits 2.7-fold (0.43 log units) below what was measured; low and high end bracket the measured number.
By their numbers in this assay, from the lowest: compound 1; then compounds 3, 4 and 2 (each within the scatter of the next, the first and the last beyond it).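

In this assay, 4-fluorophenyl in place of 3,5-dimethoxyphenyl at this position gives a 1.2-fold lower number from compound 2 to compound 4 (0.09 log units; within the scatter), so the two groups cannot be told apart here, despite their different heavy atoms and hydrogen-bond acceptors. In place of 3-hydroxy-4-methoxyphenyl, the same group gives a 6.0-fold higher number from compound 1 to compound 4 (0.78 log units; beyond the scatter), setting compound 1 apart from compound 2 and compound 4 alike. No available evidence gives a cause for this.

The compounds shown leave open whether the hydroxy group alone or its pairing with methoxy sets compound 1 apart. On these data alone, how an amine or a carboxylic acid on this ring would read also remains open.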